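Chain homologues of the chloromethyl ketone series

This account rests on a few compounds, and the source may have more. Where it says the series, first, only, none or still open, it means among the compounds named here.

Of the compounds shown here, three have a number so far. In a functional assay on MOLT-3 cells (Homo sapiens) (on this read-out lower numbers stand for stronger inhibition and higher numbers for weaker inhibition), compound 1 `CCSC[C@H](NC(C)=O)C(=O)CCl` gives 99900 nM, compound 2 `CCCSC[C@H](NC(C)=O)C(=O)CCl` gives 8000 nM and compound 3 `CCCCSC[C@H](NC(C)=O)C(=O)CCl` gives 5600 nM. Compound 3 holds the lowest of the three numbers, but its gap to compound 2 sits within the scatter, so the two cannot be ordered; only compound 1 stands apart, by an 18-fold lower number from compound 1 to compound 3 (1.25 log units; beyond the scatter).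

Compound 4 `CCCCCSC[C@H](NC(C)=O)C(=O)CCl` continues the chain: methyl in place of hydrogen on a saturated chain carbon, four bonds along the chain from a sulfur. The same kind of change gave a 12-fold lower number from compound 1 to compound 2 (1.10 log units; beyond the scatter), yet the next cut of the same kind gave only a 1.4-fold lower number from compound 2 to compound 3 (0.15 log units; within the scatter), so the gain shrank sharply from the first homologue to the second. On that basis only a small step is expected in this assay from compound 3 to compound 4, if any beyond the scatter, in the direction of a lower number: a 1.4-fold lower number from compound 3 to compound 4 (0.15 log units; within the scatter).

For compound 4 the estimate in this assay is 4000 nM, with a range from 1500 nM to 12000 nM.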

Compound 4, half-maximal inhibitory concentration: 5400 nM
Estimate against measurement, compound 4: 1.4-fold (0.13 log units) below; low and high end bracket the measured number.
By their numbers in this assay, from the lowest: compounds 4, 3 and 2 (each within the scatter of the next); then compound 1.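

Methyl at this place, four bonds along the chain from a sulfur, brings no readable change in this assay: a 1.0-fold lower number from compound 3 to compound 4 (0.02 log units; within the scatter). Compound 2 also stays within the scatter of the new compound, with a 1.5-fold lower number from compound 2 to compound 4 (0.17 log units; within the scatter), so the three longer chains form one level and only compound 1 stands apart, with a 19-fold lower number from compound 1 to compound 4 (1.27 log units; beyond the scatter). The earlier compounds gave two steps of differing size; the new one shows that the same methyl-for-hydrogen change can be large on the shortest chain and unreadable further out: the same change on two cores in this assay, a 12-fold lower number (1.10 log units; beyond the scatter) from compound 1 to compound 2 and a 1.0-fold lower number (0.02 log units; within the scatter) from compound 3 to compound 4, 12-fold (1.08 log units) apart, beyond the scatter of two such steps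

As far as these compounds go, whether this level holds for a longer chain, such as hexyl or octyl, remains open. Also open, from the compounds shown here alone, is how an amine or a carboxylic acid at the chain end would stand against the plain alkyl chains.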